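The source may hold more compounds than are shown below. What is called first, only, known or untested is meant among the compounds shown, and "the series" means these compounds.

Working notes on the series. Among the compounds with values here, compound 1 `N#CC1CN1C(=O)Nc1ccccc1` is the only member with a numerical read-out: in a functional assay on L1210 cells (Mus musculus) for cytotoxicity, read by MTT assay (on this read-out higher numbers stand for weaker inhibition and lower numbers for stronger inhibition), compound 1 gives 1200 nM; 38400 nM (2 entries), two entries that sit far apart from one another (the several entries of compound 1 in this assay, 1200 nM; 38400 nM (2 entries)). Within the data shown here, compound 2 `NC(=O)N1CC1C1=NC(C(=O)O)CS1` differs from compound 1 in more than one place, so no single step between the two is counted. In this assay compound 2 returns only a limit of the assay, > 500000 nM, and no single number stands for it (the limit of > 500000 nM in this assay, at which 1 of the 2 values shown sits).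

Compound 3 `CNC(=O)N1CC1C1=NC(C(=O)O)CS1` differs from compound 2 by methyl in place of hydrogen on an amide-type nitrogen. Among the measured compounds shown here, no measured pair shows what this methyl does in this assay. With compound 2 sitting at a limit, no step beyond the scatter is expected in either direction, and compound 3 is expected to remain at or past the limit. Compound 3 is estimated at 700000 nM with a range of 100000 nM to 5000000 nM, which means an expected step that the limit leaves unreadable from compound 2 to compound 3 of no size beyond the scatter.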

Compound 3, half-maximal inhibitory concentration: > 500000 nM
Compound 3: only a limit was reported; the forecaster's own chance of this, stated with the estimate: 85%; the middle value is on the limit's open side.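

Compound 2 and compound 3 both stand only as limits of the assay, and no step can be read between them. The compounds shown leave open what methyl in place of hydrogen on an amide-type nitrogen does to the read-out in this assay.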